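Swapping the Triazole for a Thiadiazole on Sulfur

This account rests on a few compounds, and the source may have more. Where it says the series, first, only, none or still open, it means among the compounds named here.

For the measured compounds named here, compound 1 `O=C(Nc1cc(Sc2ncn[nH]2)c(O)c2ccccc12)c1ccc(Cl)cc1` is the only one of three measured compounds to give a number in a functional assay on HCT-116 cells (Homo sapiens) for antiproliferative activity, read by MTT assay, with a stated time of 48 h; on this read-out lower numbers stand for stronger inhibition and higher numbers for weaker inhibition; compound 1 gives 43300 nM. Compound 2 `COc1ccc(C(=O)Nc2cc(Sc3ncn[nH]3)c(O)c3ccccc23)cc1`, with methoxy in place of chloro on an aromatic carbon, gives > 100000 nM, which is a limit of the assay and not a number. Compound 3 `O=C(/C=C/c1ccc(Cl)cc1)Nc1cc(Sc2ncn[nH]2)c(O)c2ccccc12`, with 2-(4-chlorophenyl)ethenyl in place of 4-chlorophenyl on a carbonyl carbon, gives > 100000 nM, again a limit. The two measured steps are an at least 2.3-fold higher number from compound 1 to compound 2 (0.36 log units; beyond the scatter) and an at least 2.3-fold higher number from compound 1 to compound 3 (0.36 log units; beyond the scatter), and both sit on the amide side of the shared core, ending at the limit of > 100000 nM in this assay, at which 2 of the 3 values shown sit.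

Compound 4 `O=C(Nc1cc(Sc2nncs2)c(O)c2ccccc12)c1ccc(Cl)cc1` differs from compound 1 elsewhere: 1,3,4-thiadiazol-2-yl in place of 1H-1,2,4-triazol-5-yl on a sulfur. Going by the values given here, neither measured step touches the ring on the sulfur, so no measured step bears directly on this change, and nothing in the data points to a direction. The outcome expected for compound 4 in this assay is therefore 50000 nM, within 15000 nM to 150000 nM. This expected step, a 1.2-fold higher number from compound 1 to compound 4 (0.06 log units; within the scatter), is estimated to stay within the usual scatter, with a real chance that only a limit is reported.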

Compound 4, half-maximal inhibitory concentration: > 100000 nM
Compound 4 was reported as a limit; the forecaster's own chance of this, stated with the estimate: 35%; at least 2.0-fold (0.30 log units) between middle value and limit.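

Changing the ring on the sulfur matters in this assay, since 1,3,4-thiadiazol-2-yl in place of 1H-1,2,4-triazol-5-yl gives an at least 2.3-fold higher number from compound 1 to compound 4 (0.36 log units; beyond the scatter). Compound 4 gives > 100000 nM, which is a limit of the assay and not a number, so only the smallest possible size of this step is known. The amide side is therefore no longer the only place where a change to compound 1 weakens the read-out, and compound 1 remains the only compound with a number: the limit of > 100000 nM in this assay, at which 3 of the 4 values shown sit.

Compound 2, compound 3 and compound 4 all stand at limits, so the steps among them cannot be read. From the compounds shown here alone, it remains open whether a different group on the sulfur, such as a tetrazole ring or a short chain ending in a carboxylic acid, would give a number in this assay.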